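The source may hold more compounds than are shown below. What is called first, only, known or untested is meant among the compounds shown, and "the series" means these compounds.

Compound 1 `Nc1nc(OCC(F)(F)F)c2ncn(/C=C3/CC3(CO)CO)c2n1` carries 2,2,2-trifluoroethoxy on an aromatic carbon of the shared core. In an ADME assay on CCRF-HSB-2 cells (Homo sapiens) for cytotoxicity, with a stated time of 7 days (on this read-out higher numbers stand for lower toxicity in this test and lower numbers for higher toxicity in this test), compound 1 gives > 20000 nM, a limit of the assay and not a number. Compound 2 `C=CCOc1nc(N)nc2c1ncn2/C=C1/CC1(CO)CO` has vinyl in place of trifluoromethyl on a saturated chain carbon bound to an oxygen on an aromatic ring. In this assay compound 2 gives > 20000 nM, again a limit. Compound 3 `COCCOc1nc(N)nc2c1ncn2/C=C1/CC1(CO)CO` has methoxymethyl in place of trifluoromethyl on a saturated chain carbon bound to an oxygen on an aromatic ring. In this assay compound 3 gives > 20000 nM, also a limit. The steps a step that the two limits leave unreadable from compound 1 to compound 2, a step that the two limits leave unreadable from compound 1 to compound 3 and a step that the two limits leave unreadable from compound 2 to compound 3 cannot be sized, because the limit of > 20000 nM in this assay, at which 3 of the 3 values shown sit, places every measured compound at the same boundary.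

Compound 4 `Nc1nc(N2CCCC2)c2ncn(/C=C3/CC3(CO)CO)c2n1` differs from compound 1 by pyrrolidin-1-yl in place of 2,2,2-trifluoroethoxy on an aromatic carbon. Within the data shown here, no measured step exchanges the ether oxygen for a ring nitrogen at this carbon, so the measured series bears on the new step only by showing that varied substituents at this position all stay at the limit. On that basis the expected step is a step that the limit leaves unreadable from compound 1 to compound 4, meaning none beyond the scatter. Compound 4 is therefore estimated at 25000 nM, in a range from 8000 nM to 80000 nM.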

Compound 4, half-maximal cytotoxic concentration: > 20000 nM
Compound 4 gave a limit, no number (the forecaster's own chance of this, stated with the estimate: 75%); the middle value does not contradict the limit.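

Among these compounds, compound 4 also sits at a limit in this assay, so no step from compound 1, compound 2 or compound 3 to compound 4 can be read: the limit of > 20000 nM in this assay, at which 4 of the 4 values shown sit. The compounds shown leave open whether any group on this aromatic carbon of the shared core gives a cytotoxic concentration that can be read as a number, and how these four compounds rank.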